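A few compounds are considered here, and "the series" means these few. Any claim that something is new, unique, unknown or untested is made for them only; others in the source may bear on it.

Working notes on the series. Three compounds are measured and a fourth, compound 4 `O=C(Nc1ccc(OCc2nc3ccccc3s2)cc1)Nc1ccc(Cl)c(Cl)c1`, is not. Compound 1 `Cc1cc(OCc2nc3ccccc3s2)ccc1NC(=O)Nc1ccc(Cl)c(Cl)c1`, compound 2 `Cc1cc(OCc2nc3ccccc3s2)ccc1NC(=O)Nc1ccccc1` and compound 3 `O=C(Nc1ccccc1)Nc1ccc(OCc2nc3ccccc3s2)cc1` have been run in an assay on isolated protein for inhibition of Polyunsaturated fatty acid 5-lipoxygenase (Homo sapiens), read by HPLC, with a stated time of 10 min; a higher number here means a weaker inhibitor, a lower number a stronger inhibitor. Compound 1 gives 230 nM, compound 2 gives 730 nM and compound 3 gives 420 nM. The cores of compound 2 and compound 3 differ by hydrogen in place of methyl on an aromatic carbon, and the step of a 1.7-fold lower number from compound 2 to compound 3 (0.24 log units; within the scatter) lies within the scatter; compound 3 and compound 1 are also within the scatter of each other. For the measured compounds named here, the change 3,4-dichlorophenyl in place of phenyl on an amide-type nitrogen produced the step of a 3.2-fold lower number from compound 2 to compound 1 (0.50 log units; beyond the scatter), the one step here that lies beyond the scatter. Compound 4 is reached from compound 3 by the same change, (3,4-dichlorophenyl in place of phenyl on an amide-type nitrogen), at the same place, an amide-type nitrogen whose other neighbour is a carbonyl carbon; the two pairs differ only in their cores, as noted. With a single prior example to rest on, a step of similar size is expected, a 3.0-fold lower number from compound 3 to compound 4 (0.48 log units; beyond the scatter), because the earlier step of a 3.2-fold lower number from compound 2 to compound 1 (0.50 log units; beyond the scatter) was beyond the scatter. Compound 4 is therefore expected to give about 140 nM in this assay. The expected range for compound 4 runs from 70 nM to 300 nM.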

Compound 4, half-maximal inhibitory concentration: 570 nM
The estimate for compound 4 lay 4.1-fold (0.61 log units) below the measured number; the measured number lies above the stated range.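

On the core of compound 3, the change to 3,4-dichlorophenyl gives a 1.4-fold higher number from compound 3 to compound 4 (0.13 log units; within the scatter) in this assay and does not reproduce the step seen on the methyl-bearing core: the same change on two cores in this assay, a 3.2-fold lower number (0.50 log units; beyond the scatter) from compound 2 to compound 1 and a 1.4-fold higher number (0.13 log units; within the scatter) from compound 3 to compound 4, 4.3-fold (0.63 log units) apart, beyond the scatter of two such steps. Read the other way, with 3,4-dichlorophenyl in place, hydrogen in place of methyl on an aromatic carbon gives a 2.5-fold higher number from compound 1 to compound 4 (0.39 log units; beyond the scatter) and does not match the step seen with phenyl: the same change on two cores in this assay, a 1.7-fold lower number (0.24 log units; within the scatter) from compound 2 to compound 3 and a 2.5-fold higher number (0.39 log units; beyond the scatter) from compound 1 to compound 4, 4.3-fold (0.63 log units) apart, beyond the scatter of two such steps. The two changes therefore do not act independently across these four compounds, so the effect of the 3,4-dichlorophenyl change cannot be assumed to carry from one core to the other, but this single set of pairs does not show why or how other cores would respond.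

On these data alone, it remains open whether this dependence on the methyl group extends to other groups on the amide-type nitrogen, such as methoxyphenyl or a pyridine ring. As far as these compounds go, it is also open whether ethyl or chlorine on that aromatic carbon would behave like methyl or like hydrogen.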